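A few compounds are considered here, and "the series" means these few. Any claim that something is new, unique, unknown or untested is made for them only; others in the source may bear on it.

Compound 2, `O=C(O)Cc1sc(Nc2ccccc2)nc1-c1ccc(F)cc1`, stands at > 70% in an in vitro functional assay on HEK285-7 cells for antagonist activity at prostaglandin D2 receptor 2 (Homo sapiens), read by BRET and beta-arrestin recruitment (a higher number here means a larger maximal response, a lower number a smaller maximal response), which is a limit of the assay and not a number. Compound 1, `O=C(O)Cc1sc(Nc2ccccc2)nc1-c1ccccc1`, likewise gives > 70%, again a limit. Going by the values given here, the one measured step, a step that the two limits leave unreadable from compound 1 to compound 2, therefore has no readable size, since (the limit of > 70% in this assay, at which 2 of the 2 values shown sit). Compound 3, `COc1ccc(-c2nc(Nc3ccccc3)sc2CC(=O)O)cc1`, differs from compound 2 by methoxy in place of fluoro on an aromatic carbon, para to a large group. With both measured compounds at the limit, no step beyond the scatter is expected in this assay; the expected step is a step that the limit leaves unreadable from compound 2 to compound 3. Compound 3 is estimated at 85%, between 70% and 100%.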

Compound 3, largest response reached (reported as efficacy), in percent of the reference or control that the assay uses: > 70%
Compound 3: no number, only a limit; the forecaster's own chance of this, stated with the estimate: 80%; the middle value does not contradict the limit.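

In this assay compound 3 gives > 70% and this is a limit, not a number. Going by these compounds alone, no step among compound 1, compound 2 and compound 3 can be read. The compounds shown leave open whether hydrogen, fluoro and methoxy differ at all in maximal response.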